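Swapping an Aromatic Arm for a Branched Chain

A few compounds are considered here, and "the series" means these few. Any claim that something is new, unique, unknown or untested is made for them only; others in the source may bear on it.

Three close relatives of one shared core have been tested in an ADME assay on MDBK cells (Bos taurus) for cytotoxicity; on this read-out higher numbers stand for lower toxicity in this test and lower numbers for higher toxicity in this test. Compound 1 `Fc1cccc(F)c1Cn1cccc2nc(-c3c(F)cccc3F)nc1-2` gives only a limit there, > 100000 nM, not a number. Compound 2 `COc1cccc(Cn2ccc3nc(-c4ccccc4)nc-3c2)c1` likewise reaches only the limit > 100000 nM in this assay. Compound 3 `CC(c1ccccc1)n1ccc2nc(-c3ccccc3)nc-2c1` also stops at the limit > 100000 nM in this assay. Within the data shown here, compound 2 therefore stands where every measured compound stands, at the limit of > 100000 nM in this assay, at which 3 of the 3 values shown sit; none of the three gives a number, so no order among them can be read, and no step between measured compounds is known.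

Compound 4 `CCC(CC)Cn1ccc2nc(-c3ccccc3)nc-2c1` differs from compound 2 in one place: pentan-3-yl in place of 3-methoxyphenyl on a saturated chain carbon bound to an aromatic nitrogen. The side group on the saturated chain carbon bound to an aromatic nitrogen thus changes from an aromatic ring to a branched chain, while the shared core is untouched.

Because every value shown sits at the limit of > 100000 nM in this assay, at which 3 of the 3 values shown sit, no change beyond the scatter is expected from this exchange, and the expected step from compound 2 to compound 4 in this assay is a number no higher from compound 2 to compound 4 (the limit leaves the size open). Compound 4 is therefore estimated at 100000 nM in this assay, with a range from 50000 nM to 300000 nM, and the assay will most likely again report only its limit.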

Compound 4, half-maximal cytotoxic concentration: > 100000 nM
Compound 4: a limit, no number; the forecaster's own chance of this, stated with the estimate: 85%; the middle value sits exactly at the limit.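

No step from compound 2 to compound 4 can be read in this assay, since each gives only a limit and not a number: the limit of > 100000 nM in this assay, at which 4 of the 4 values shown sit.

The compounds shown leave open whether any group on the saturated chain carbon bound to an aromatic nitrogen would give a true number, and how the four compounds would rank if they had numbers.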